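Ring contraction at the amine of compound 2

The source may hold more compounds than are shown below. What is called first, only, known or untested is meant among the compounds shown, and "the series" means these compounds.

Measured compounds:
compound 1 `CN(c1ccc(Oc2ncnc3sccc23)cc1)c1nccc(N2CCc3ccccc3C2)n1`: 57.7%
compound 2 `CN(c1ccc(Oc2ncnc3ccsc23)cc1)c1nccc(N2CCc3ccccc3C2)n1`: 58.3%

Both compounds were tested in a functional assay on HCT-116 cells (Homo sapiens) for inhibition, read by MTT assay, with a stated time of 72 h, tested at 20 uM; a lower number here means less inhibition, a higher number more inhibition at the concentration tested (going by the name of the read-out). Compound 1 gave 57.7% and compound 2 gave 58.3%, so compound 2 holds the higher of the two numbers, but the step of a number 0.6 percentage points higher from compound 1 to compound 2 (within the scatter), and the two values cannot be told apart.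

Compound 3 `CN(c1ccc(Oc2ncnc3ccsc23)cc1)c1nccc(N2CCc3ccccc32)n1` has not been measured. It is compound 2 with 2,3-dihydro-1H-indol-1-yl in place of 1,2,3,4-tetrahydroisoquinolin-2-yl on an aromatic carbon. Within the data shown here, the one measured step concerns the arrangement of the heteroaromatic ether part and leaves the amine untouched, so no measured step bears on this change; the expectation rests on the two values alone. Because compound 2 shows 58.3%, compound 3 is expected to sit near it, with a step of a number 8.3 percentage points lower from compound 2 to compound 3 (within the scatter). The estimated value of compound 3 is 50%, within a range from 25% to 75%.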

Compound 3, a percentage reported as inhibition, at one concentration (the size of the read-out at that concentration, not a potency): 57.8%
Beside the measured number, compound 3's estimate is 7.8 percentage points below it, within the range that was stated.
By their numbers in this assay, from the lowest: compounds 1, 3 and 2 (each within the scatter of the next).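

Among these compounds, compound 3 gives the first measured change at the amine, and with 2,3-dihydro-1H-indol-1-yl in place of 1,2,3,4-tetrahydroisoquinolin-2-yl, this assay shows a number 0.5 percentage points lower from compound 2 to compound 3 (within the scatter) as the step. At this one concentration, the read-out therefore does not separate the five-membered non-aromatic ring from the six-membered one at this place, on an aromatic carbon next to the ring nitrogen. No evidence is available that would account for this result.

The compounds shown leave open whether an open-chain amine such as dimethylamino, or a morpholine ring, would give a number in the same region at this place. They also leave open whether the same exchange of rings would read alike on the core of compound 1, and how these compounds compare in potency across a range of concentrations.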